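This account rests on a few compounds, and the source may have more. Where it says the series, first, only, none or still open, it means among the compounds named here.

Values in a functional assay on SGC-7901 cells (Homo sapiens) for cytotoxicity, read by MTT assay, with a stated time of 48 h (a higher number here means a weaker inhibitor, a lower number a stronger inhibitor), for the series so far

compound 1 `CC1=NN(C(=O)c2ccccc2)C(c2ccccc2O)C1` gives 21200 nM
compound 2 `CC1=NN(C(=O)c2ccc(C)cc2)C(c2ccccc2O)C1` gives 51500 nM
compound 3 `CC1=NN(C(=O)c2ccccc2C)C(c2ccccc2O)C1` gives 104000 nM

Compound 1 has the lowest number of the three, and its steps to both others lie beyond the scatter. Still unmeasured is compound 4 `CC1=NN(C(=O)c2ccccc2)C(c2cccc(C)c2O)C1`, which differs from compound 1 by one change (methyl in place of hydrogen on an aromatic carbon), a methyl in place of hydrogen on an aromatic carbon, ortho to a hydroxy group.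

Two measured steps are the same kind of replacement: a 2.4-fold higher number from compound 1 to compound 2 (0.39 log units; beyond the scatter) and a 4.9-fold higher number from compound 1 to compound 3 (0.69 log units; beyond the scatter). Both are modest and both raise the number. The outcome also differs with the place of the methyl, as a 2.0-fold higher number from compound 2 to compound 3 (0.31 log units; beyond the scatter) shows. These methyl groups sit on the aryl group attached to the carbonyl, whereas the new methyl sits on the ring carrying the hydroxy group. Going by the values given here, no measured compound varies that ring, so the transfer is loose. A modest rise in this assay is therefore expected, with a range wide enough to include no real change. The expected size is a 2.1-fold higher number from compound 1 to compound 4 (0.33 log units; beyond the scatter). Compound 4 is estimated at 45000 nM, with an expected range of 15000 nM to 130000 nM.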

Compound 4, half-maximal inhibitory concentration: 150000 nM
Beside the measured number, compound 4's estimate is 3.3-fold (0.52 log units) below it; measured number above the stated range.
By their numbers in this assay, from the lowest: compound 1; then compound 2; then compounds 3 and 4 (each within the scatter of the next).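

In this assay, the ring carrying the hydroxy group also responds to substitution: a methyl ortho to a hydroxy group gives a 7.1-fold higher number from compound 1 to compound 4 (0.85 log units; beyond the scatter). Methyl in place of hydrogen on an aromatic carbon now raises the number at all three places shown, on both aryl groups, and none of compounds 2, 3 and 4 goes against this; compound 1, the unsubstituted member, remains the lowest at 21200 nM. Nothing available on this series accounts for the rise at this position.

The compounds shown leave open whether a chlorine, a methoxy or an amine at this same place would also raise the number, and whether a methyl elsewhere on the ring carrying the hydroxy group would do the same. Every compound shown also keeps the hydroxy group itself, so the outcome of replacing it with a methoxy or a carboxylic acid remains unknown, as does whether any substituent on either ring can bring the number below that of compound 1.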